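Swapping a Sulfone Chain for an Ether Chain

The source may report more compounds than this note shows. Statements on the series, on what has been measured and on what is new or still open speak of the compounds shown alone.

Compound 1 `CS(=O)(=O)CCn1c(Cn2cc(S(C)(=O)=O)c3ccccc32)nc2ccccc21`: > 100000 nM
Compound 2 `CS(=O)(=O)CCCn1c(Cn2nc(S(C)(=O)=O)c3ccncc32)nc2cc(Cl)ccc21`: > 100000 nM

In an ADME assay on HEp-2 cells (Homo sapiens) for cytotoxicity, with a stated time of 4 days (a lower number here means that less compound is tolerated, a higher number that more compound is tolerated), compound 1 gives > 100000 nM, which is a limit of the assay and not a number. Compound 2 in this assay gives > 100000 nM, again a limit. Compound 2 therefore stands at the limit of > 100000 nM in this assay, at which 2 of the 2 values shown sit, with nothing measured beyond it. Compound 3 `COCCOCCn1c(Cn2nc(S(C)(=O)=O)c3ccncc32)nc2cc(Cl)ccc21` differs from compound 2 by 2-methoxyethoxy in place of (methylsulfonyl)methyl on a saturated chain carbon, two bonds along the chain from an aromatic nitrogen. Within the data shown here, no step between measured compounds exists to size this change. The expected step is a number no higher from compound 2 to compound 3 (the limit leaves the size open), nothing beyond the scatter. Compound 3 is expected to give 100000 nM, most likely again only a limit, in the range 40000 nM to 300000 nM.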

Compound 3, half-maximal cytotoxic concentration: > 100000 nM
Compound 3 gave a limit, no number; the forecaster's own chance of this, stated with the estimate: 85%; the middle value sits exactly at the limit.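

Compound 2 and compound 3 each give only a limit, not a number, so no step can be read between them. Still open, as far as these compounds go, is the concentration at which any of the three compounds becomes toxic to the cells, and whether 2-methoxyethoxy in place of (methylsulfonyl)methyl shifts it.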